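This account rests on a few compounds, and the source may have more. Where it says the series, first, only, none or still open, it means among the compounds named here.

Measured in a functional assay on HL-60 cells (Homo sapiens) for antiproliferative activity, read by XTT assay, with a stated time of 72 h; on this read-out lower numbers stand for stronger inhibition and higher numbers for weaker inhibition:

- compound 1 `C=C(C)CC[C@]1(C)C2=CCC[C@](C)(C[C@H](O)c3ccoc3)[C@H]2CC[C@H]1C`: 28700 nM
- compound 2 `CC(C)=CCC[C@]1(C)C2=CCC[C@](C)(CC(=O)c3ccoc3)[C@H]2CC[C@H]1C`: 57800 nM
- compound 3 `C=C(C)CCC[C@]1(C)C2=CCC[C@](C)(C[C@@H](OC(C)=O)C3=CC(=O)OC3O)[C@H]2CC[C@H]1C`: 3200 nM

Compound 1 gives 28700 nM, which lies within the usual scatter of compound 2. Compound 3 stands clearly apart, with a lower number that means stronger inhibition. Compound 1 therefore belongs to the weaker end of this small set.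

The next compound to be tested is compound 4 `C=C(C)CC[C@]1(C)C2=CCC[C@](C)(C[C@@H](O)c3ccoc3)[C@H]2CC[C@H]1C`. It has the same atoms and bonds as compound 1 and differs only in configuration as drawn: the two compounds have the same atoms and bonds and differ only in configuration as drawn: 1 of 5 stereo elements differ; a stereocentre at a saturated chain carbon is drawn S in compound 1 and R in compound 4. Such a pair of mirror-related centres can behave alike or differently, and no measured pair here shows a change of this kind. The expectation in this assay is therefore no step beyond the scatter, and no direction is favoured.

The estimated change is a 1.0-fold higher number from compound 1 to compound 4 (0.02 log units; within the scatter). For compound 4 the expected value is 30000 nM, with an estimated range of 12000 nM to 70000 nM.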

Compound 4, half-maximal inhibitory concentration: 28700 nM
Compound 4: the middle estimate sits 1.0-fold (0.02 log units) above what was measured; measured number inside the range.
By their numbers in this assay, from the lowest: compound 3; then compounds 1, 4 and 2 (each within the scatter of the next).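

Within the data shown here, this is the first pair in the set that differs in one place, so it is the first direct reading of a single change. In this assay the step shows no change at the digits printed from compound 1 to compound 4 (within the scatter). Turning this one stereocentre from S to R therefore leaves the antiproliferative read-out where it was, and for this pair the drawn configuration at that saturated chain carbon makes no visible difference, which can be read cleanly since nothing else separates the two: the fact that compounds 1 and 4 differ only in the configuration as drawn

From the compounds shown here alone, whether this indifference holds only for the hydroxyl group remains open, since an amine in its place might respond to the same inversion differently. The pair also cannot say why the two configurations read alike, or whether they would do so on cells other than these.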